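Taking the methoxy group off compound 2

The compounds below may be only part of what the source reports. "The series", "measured", "known", "first", "only" and "open" are said of these compounds alone.

Compound 1 `N#Cc1ccc(C(=O)Nc2ccc(F)c([C@]3(C4CC4)C=C(CF)OC(N)=N3)c2)nc1`: 6.8
Compound 2 `COCC1=C[C@@](C)(c2cc(NC(=O)c3ccc(C#N)cn3)ccc2F)N=C(N)O1`: 7.4

Both compounds were measured in a physicochemical assay for acid dissociation, read by capillary electrophoresis. Compound 2, at 7.4, has the higher of the two numbers, and compound 1 gives 6.8, a gap beyond the usual scatter. These two compounds differ in more than one place, so their gap does not show the size of any single change.

The next compound, compound 3 `CC1=C[C@@](C)(c2cc(NC(=O)c3ccc(C#N)cn3)ccc2F)N=C(N)O1`, comes from compound 2 through one change hydrogen in place of methoxy on a saturated chain carbon bound to a double-bonded ring carbon, so methoxymethyl becomes methyl. Among the compounds with values here, no measured pair shows this change directly. A moderate rise in this assay, beyond the scatter, is expected. The estimated value for compound 3 is 7.9, with an expected range from 7.5 to 8.3. This estimate amounts to a number 0.50 log units higher from compound 2 to compound 3 (beyond the scatter).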

Compound 3, acid dissociation constant: 7.9
Compound 3: the middle estimate sits on the measured number at the digits printed; measured number inside the range.
By their numbers in this assay, from the lowest: compound 1; then compound 2; then compound 3.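

In this assay, putting hydrogen in place of methoxy on a saturated chain carbon bound to a double-bonded ring carbon gives a number 0.50 log units higher from compound 2 to compound 3 (beyond the scatter). This is the only pair shown that differs in one place, so it puts a size on a single change, methoxymethyl to methyl, at this position, which the gap between compound 1 and compound 2 could not do. No measurement at hand bears on the reason for this step.

The compounds shown leave open whether the same change would give a step of similar size on the core of compound 1. They also leave open where a longer chain such as ethyl, or an amine such as aminomethyl, would place the number at this position.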